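The compounds below may be only part of what the source reports. "The series", "measured", "known", "first", "only" and "open" are said of these compounds alone.

Measured compounds:
compound 1, `CC(C)(C)c1ccc(C(=O)NCc2ccc(NS(C)(=O)=O)cc2)cc1` — 44 nM
compound 2, `CC(C)(C)c1ccc(C(=O)NCc2ccc(S(C)(=O)=O)cc2)cc1` — 3800 nM

In an assay on HeLa cells with Bile acid receptor (Homo sapiens) as the target, read by a luciferase reporter, with a stated time of 24 h (a higher number here means that more compound is needed for the effect, a lower number that less compound is needed), compound 1 gives 44 nM, and compound 2 gives 3800 nM. Among the measured compounds shown here, compound 2 thus stands at the higher of the two numbers, and the single measured step, an 86-fold higher number from compound 1 to compound 2 (1.94 log units; beyond the scatter), is a large one. Compound 3, `COc1ccc(CNC(=O)c2ccc(C(C)(C)C)cc2)cc1`, is not yet measured in this assay. Its change from compound 2 is methoxy in place of methylsulfonyl on an aromatic carbon. For the measured compounds named here, the one measured step bears on this change only in part: it shows that the group at this position, para to a large group, can move the number in this assay a great deal, but no measured compound carries a methoxy there, and neither compound 1 nor compound 2 tells whether a methoxy will fall nearer one or the other. Going by the values given here, since compound 2 already stands at the high end, and the only known step at this site was large, the account expects the number for compound 3 to differ from compound 2 by a step of a 2.5-fold lower number from compound 2 to compound 3 (0.40 log units; beyond the scatter), most likely toward a lower number, though with wide uncertainty. The estimate for compound 3 in this assay is 1500 nM, with a range from 300 nM to 8000 nM.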

Compound 3, half-maximal effective concentration: 150 nM
Estimate against measurement, compound 3: 10-fold (1.00 log units) above; the measured number lies below the stated range.
By their numbers in this assay, from the lowest: compound 1; then compound 3; then compound 2.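

In this assay, exchanging the methylsulfonyl on this aromatic carbon, para to a large group, for a methoxy gives a 25-fold lower number from compound 2 to compound 3 (1.40 log units; beyond the scatter). This shows that the large effect at this position is not confined to the step between the two sulfur-bearing groups, and that a group with no sulfur can bring the number far down from that of compound 2. The methanesulfonamido group still gives the lowest number of the three, with a 3.4-fold higher number from compound 1 to compound 3 (0.53 log units; beyond the scatter), so the methoxy recovers much of the difference without matching it, and the order runs from compound 1 through compound 3 to compound 2. Nothing available explains why the three groups fall in this order.

On these data alone, it remains open whether a hydroxyl, an amine or an ethoxy on this carbon would fall nearer compound 1 or compound 3, or whether a carboxylic acid would give a number closer to that of compound 2. The three compounds also leave open whether this order of groups would hold if another part of the shared core were changed.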